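The compounds below may be only part of what the source reports. "The series", "measured", "known", "first", "only" and "open" are said of these compounds alone.

In a functional assay with Homo sapiens as the target (a lower number here means a stronger inhibitor, a higher number a weaker inhibitor), compound 1 `CC(C)[C@H](NC(=O)COc1cccc2ccccc12)C(=O)N[C@@H](CC(=O)O)C(=O)COc1ccccc1C(F)(F)F` gives 17300 nM, and compound 2 `CC(C)[C@H](NC(=O)COc1cccc2ccccc12)C(=O)N[C@@H](CC(=O)O)C(=O)COc1cccc(F)c1` gives 12000 nM. These two compounds share one core and differ only in the ring carried on an oxygen on a saturated carbon. Compound 2 has the lower number, but the gap is small enough that the two stand level: the measured step is a 1.4-fold lower number from compound 1 to compound 2 (0.16 log units; within the scatter).

Compound 3 `CC(C)[C@H](NC(=O)COc1cccc2ccccc12)C(=O)N[C@@H](CC(=O)O)C(=O)COc1ccc(F)cc1` has not yet been measured. It keeps everything in compound 2 except for one change at that same place, with 4-fluorophenyl in place of 3-fluorophenyl on an oxygen on a saturated carbon.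

Going by the values given here, only one measured step bears on this change. Swapping 2-(trifluoromethyl)phenyl for 3-fluorophenyl at this place gave a 1.4-fold lower number from compound 1 to compound 2 (0.16 log units; within the scatter), so even that larger change of group left the number within the scatter. Among the compounds with values here, no measured compound carries 4-fluorophenyl, so this evidence is thin, and no shift beyond the scatter is expected in this assay. The expected step is no change at the digits printed from compound 2 to compound 3 (within the scatter). Compound 3 is estimated at 12000 nM, with an expected range from 5500 nM to 26000 nM.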

Compound 3, half-maximal inhibitory concentration: 14300 nM
The estimate for compound 3 lay 1.2-fold (0.08 log units) below the measured number; low and high end bracket the measured number.
By their numbers in this assay, from the lowest: compounds 2, 3 and 1 (each within the scatter of the next).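

In this assay, the 4-fluorophenyl group in place of the 3-fluorophenyl group gives a 1.2-fold higher number from compound 2 to compound 3 (0.08 log units; within the scatter) and so leaves the number within the scatter, the first measured case here in which the entering and leaving groups have the same atoms, joined differently. Set against the 2-(trifluoromethyl)phenyl group, the 4-fluorophenyl group gives a 1.2-fold lower number from compound 1 to compound 3 (0.08 log units; within the scatter) in the same assay, so all three substituted phenyl groups on this oxygen now stand level and this small set shows no preference among them. Nothing in the information available accounts for this level picture.

Still open, on these data alone, is whether this position stays as flat once the ring carries something other than fluorine or trifluoromethyl, such as an amine, or once a longer saturated carbon chain replaces the ring altogether. All three compounds also share one core, so these numbers say nothing about how a change elsewhere in the molecule would read, or whether any group at this position could move the number beyond the scatter.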